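The compounds below may be only part of what the source reports. "The series", "measured", "known", "first", "only" and "open" are said of these compounds alone.

Compound 2 `COc1ccc(CN(C(=O)CCl)c2cc(OC)c(OC)c(OC)c2)cc1O` stands second highest of three numbers in a functional assay on KYSE-450 cells (Homo sapiens) for inhibition, read by MTT assay, with a stated time of 48 h (on this read-out higher numbers stand for weaker inhibition and lower numbers for stronger inhibition), where compound 2 gives 210 nM. Its nearest neighbour is compound 1 `COc1ccc(CN(C(=O)C2CC2)c2cc(OC)c(OC)c(OC)c2)cc1O`, which gives 80 nM; the step between them reads a 2.6-fold higher number from compound 1 to compound 2 (0.42 log units; beyond the scatter). Furthest away is compound 3 `C/C=C/C(=O)N(Cc1ccc(OC)c(C)c1)c1cc(OC)c(OC)c(OC)c1`, which gives 32900 nM; no single-point step links it to compound 2. Compound 4 `COc1ccc(CN(C(=O)CCCl)c2cc(OC)c(OC)c(OC)c2)cc1O` differs from compound 2 by chloromethyl in place of chloro on a saturated chain carbon bound to a carbonyl carbon. For the measured compounds named here, no measured step changes this chain length; the only recorded step, from compound 1 to compound 2, exchanges the whole group on the carbonyl carbon and is modest. The expectation for compound 4 is therefore a modest move to a higher number in this assay, a 1.9-fold higher number from compound 2 to compound 4 (0.28 log units; within the scatter), with wide uncertainty. Compound 4 is estimated at 400 nM, range 150 nM to 1500 nM.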

Compound 4, half-maximal inhibitory concentration: 110 nM
The estimate for compound 4 lay 3.6-fold (0.56 log units) above the measured number; measured number below the stated range.
By their numbers in this assay, from the lowest: compounds 1, 4 and 2 (each within the scatter of the next, the first and the last beyond it); then compound 3.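

Extending chloromethyl to 2-chloroethyl on the carbonyl carbon gives no readable loss in this assay (a 1.9-fold lower number from compound 2 to compound 4 (0.28 log units; within the scatter)), so this position accepts the added chain carbon. The 2-chloroethyl group also stays level with cyclopropyl (a 1.4-fold higher number from compound 1 to compound 4 (0.14 log units; within the scatter)), whereas chloromethyl did not (a 2.6-fold higher number from compound 1 to compound 2 (0.42 log units; beyond the scatter)). Nothing available explains this result. As far as these compounds go, whether a longer chain such as 3-chloropropyl keeps this level remains open. So does the role of the chlorine, which a plain propyl or a 2-hydroxyethyl group on the carbonyl carbon would test.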